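Compound 3: a dimethylated variant of compound 2

The compounds below may be only part of what the source reports. "The series", "measured", "known", "first", "only" and "open" are said of these compounds alone.

In a functional assay on CWR22R cells (Homo sapiens) for antiproliferative activity, read by MTT assay, with a stated time of 3 days (on this read-out higher numbers stand for weaker inhibition and lower numbers for stronger inhibition), compound 1 (`CCS(=O)(=O)Nc1ccc(-c2cc(=O)c3c(O)cc(OC)c(OC(C)C)c3o2)cc1`) gives 2900 nM and compound 2 (`COc1cc(O)c2c(=O)cc(-c3ccc(NC(=O)N4CCNCC4)cc3)oc2c1OC(C)C`) gives 1300 nM as the lower of the two numbers, so compound 2 stands as the stronger inhibitor so far. Compound 3 (`COc1cc(O)c2c(=O)cc(-c3ccc(NC(=O)N4CC(C)NC(C)C4)cc3)oc2c1OC(C)C`) differs from compound 2 in one place (3,5-dimethylpiperazin-1-yl in place of piperazin-1-yl on a carbonyl carbon) with 3,5-dimethylpiperazin-1-yl in place of piperazin-1-yl on a carbonyl carbon. For the measured compounds named here, the only measured step bearing on this is a 2.2-fold lower number from compound 1 to compound 2 (0.35 log units; beyond the scatter) and it is modest, with (piperazin-1-yl)carbonyl in place of ethylsulfonyl on a nitrogen on an aromatic ring. That step exchanged one whole group for a quite different one, whereas the new change keeps the piperazine ring. Going by the values given here, no measured compound carries anything extra on that ring, so the direction cannot be read from the data. In this assay a step no larger than the measured one is expected, most likely none beyond the scatter. The estimate amounts to a 1.2-fold lower number from compound 2 to compound 3 (0.07 log units; within the scatter) as the expected step. Compound 3 is estimated at 1100 nM with a range from 450 nM to 2700 nM as its expected span.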

Compound 3, half-maximal inhibitory concentration: 800 nM
Estimate against measurement, compound 3: 1.4-fold (0.14 log units) above; measured number inside the range.
By their numbers in this assay, from the lowest: compounds 3 and 2 (each within the scatter of the next); then compound 1.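

In this assay, replacing piperazin-1-yl with 3,5-dimethylpiperazin-1-yl on the carbonyl carbon gives a 1.6-fold lower number from compound 2 to compound 3 (0.21 log units; within the scatter), so this position tolerates the larger ring substituent, with no difference that can be told from the usual scatter. The advantage over the ethylsulfonyl group also remains readable with the dimethylated ring in place: putting (3,5-dimethylpiperazin-1-yl)carbonyl in place of ethylsulfonyl on the nitrogen gives a 3.6-fold lower number from compound 1 to compound 3 (0.56 log units; beyond the scatter), a modest step that lies beyond the scatter. Nothing available explains these numbers, and the result gives no reason to favour one account of them over another.

The compounds shown leave open how much further this position can be changed, for instance whether a morpholin-4-yl ring or an open-chain amine on the same carbonyl carbon would give a similar number. They also leave open whether a piperazine ring carrying a single methyl group, or longer chains in place of the two methyl groups, would stay within the scatter or move clearly away from it.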